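The compounds below may be only part of what the source reports. "The series", "measured", "known", "first", "only" and "open" are said of these compounds alone.

Values in a functional assay on the whole organism with Rattus norvegicus as the target (on this read-out higher numbers stand for weaker inhibition and lower numbers for stronger inhibition), for the measured members of the series:

compound 1, `Cc1ccc(O)c(NCCCN2CCN(C(c3ccc(F)cc3)c3ccc(F)cc3)CC2)c1`: in this assay compound 1 gives 0.1 ug/mL
compound 2, `Cc1ccc(O)c(N(CCCN2CCN(C(c3ccc(F)cc3)c3ccc(F)cc3)CC2)C(C)C)c1`: in this assay compound 2 gives 1.2 ug/mL
compound 3, `Cc1ccc(O)c(NCCCN2CCC(C(O)(c3ccccc3)c3ccccc3)CC2)c1`: in this assay compound 3 gives 0.029 ug/mL

Compound 4, `Cc1ccc(O)c(N(CCCN2CCC(C(O)(c3ccccc3)c3ccccc3)CC2)C(C)C)c1`, remains to be measured. Its relation to compound 3 is isopropyl in place of hydrogen on a nitrogen on an aromatic ring, and the same change is seen between compound 1 and compound 2, (isopropyl in place of hydrogen on a nitrogen on an aromatic ring), where it produced a 12-fold higher number from compound 1 to compound 2 (1.08 log units; beyond the scatter). The two cores differ as well, but the difference between the core of compound 1 and the core of compound 3 is not broken down here; the two values show compound 3 with the lower number. Since the change and its place are the same in both pairs, a step of comparable size is expected for compound 4 in this assay, a 10-fold higher number from compound 3 to compound 4 (1.01 log units; beyond the scatter), resting on the step from compound 1 to compound 2, a 12-fold higher number from compound 1 to compound 2 (1.08 log units; beyond the scatter). Compound 4 is therefore estimated at 0.3 ug/mL, with an expected range from 0.1 ug/mL to 1 ug/mL.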

Compound 4, half-maximal inhibitory concentration: 0.79 ug/mL
Compound 4: middle estimate off by 2.6-fold (0.42 log units), on the low side; low and high end bracket the measured number.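

In this assay, isopropyl in place of hydrogen on a nitrogen on an aromatic ring gives a 27-fold higher number from compound 3 to compound 4 (1.44 log units; beyond the scatter), and the change carries over from one core to the other in direction and, within the scatter, in size: the same change on two cores in this assay, a 12-fold higher number (1.08 log units; beyond the scatter) from compound 1 to compound 2 and a 27-fold higher number (1.44 log units; beyond the scatter) from compound 3 to compound 4, 2.3-fold (0.36 log units) apart, within the scatter of two such steps. This rests on two pairs only, so it holds for the core of compound 1 and the core of compound 3 and says nothing about any other core. It also does not show why the number rises with this change.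

Open, as far as these compounds go, is whether methyl, ethyl or a longer chain on that same nitrogen would give a step of similar size. Also open, from the compounds shown here alone, is whether an acetyl group there would fit the same picture.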